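This account rests on a few compounds, and the source may have more. Where it says the series, first, only, none or still open, it means among the compounds named here.

Among the compounds with values here, compound 2 `CC1(OC(=O)N2CCC(O[C@H]3CC[C@H](Oc4cnc(S(C)(=O)=O)cn4)CC3)CC2)CC1` is one of two compounds measured in a functional assay on isolated protein for agonist activity at Glucose-dependent insulinotropic receptor (Rattus norvegicus), read by HTRF and cAMP accumulation; on this read-out lower numbers stand for smaller maximal responses and higher numbers for larger maximal responses. In this assay compound 2 gives 123%, the higher of the two numbers. The other measured compound, compound 1 `CC(C)(C)OC(=O)N1CCC(O[C@H]2CC[C@H](Oc3ccc(C#N)cc3)CC2)CC1`, gives in this assay 106%, a value that lies below that of compound 2 by a margin beyond the usual scatter of repeated measurements.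

Compound 3 `CC(F)Cc1nc(CN2CCC(O[C@H]3CC[C@H](Oc4cnc(S(C)(=O)=O)cn4)CC3)CC2)no1` has not yet been measured in this assay. It differs from compound 2 at one place only: (5-(2-fluoropropyl)-1,2,4-oxadiazol-3-yl)methyl in place of ((1-methylcyclopropyl)oxy)carbonyl on an amine nitrogen in a ring. Within the data shown here, no step between two measured compounds covers a change of this kind, so the expectation for compound 3 rests on the value of compound 2 alone and on the fact that both measured compounds reach a full or better-than-full response.

With compound 2 at 123% as the starting point, the step from compound 2 to compound 3 is expected to be small and, if anything, downward, at a number 13 percentage points lower from compound 2 to compound 3 (beyond the scatter). For compound 3 the maximal response in this assay is therefore estimated at 110%, with a range from 85% to 130%.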

Compound 3, largest response reached (Emax), in percent of the reference or control that the assay uses: 114%
Beside the measured number, compound 3's estimate is 4 percentage points below it, within the range that was stated.
By their numbers in this assay, from the lowest: compounds 1, 3 and 2 (each within the scatter of the next, the first and the last beyond it).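

In this assay, the step at the amine nitrogen in a ring, where (5-(2-fluoropropyl)-1,2,4-oxadiazol-3-yl)methyl takes the place of ((1-methylcyclopropyl)oxy)carbonyl, comes to a number 9 percentage points lower from compound 2 to compound 3 (within the scatter) and so gives no separation between the two compounds. Within the data shown here, this is the first single-place comparison, and it shows that the maximal response at this position does not depend on keeping the ((1-methylcyclopropyl)oxy)carbonyl group: a larger group with a five-membered aromatic ring in place of the three-membered carbon ring, and with no double bond outside aromatic rings, serves as well in this read-out. No measurement on hand accounts for this result.

The compounds shown leave open which part of the entering group matters, since the fluorine, the propyl chain and the methyl link to the nitrogen all enter together, and a plain propyl chain on the same five-membered ring would separate the fluorine from the rest. They also leave open whether a simple benzyl or acetyl group on that nitrogen would reach a similar maximal response, as this single step marks out no limit to what the position accepts.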